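Uridine phosphate series: methoxy for benzylsulfanyl, diphosphate loss

A few compounds are considered here, and "the series" means these few. Any claim that something is new, unique, unknown or untested is made for them only; others in the source may bear on it.

Measured so far:
compound 1 `COc1nc(=O)ccn1[C@@H]1O[C@H](COP(=O)(O)OP(=O)(O)O)[C@@H](O)[C@H]1O`; in an in vitro functional assay on 1321-N1 cells for agonist activity at P2Y purinoceptor 2 (Homo sapiens), read by scintillation proximity assay and inositol phosphate accumulation (on this read-out lower numbers stand for an effect already at smaller amounts and higher numbers for an effect only at larger amounts of compound), compound 1 gives 907 nM
compound 2 `O=c1ccn([C@@H]2O[C@H](COP(=O)(O)OP(=O)(O)O)[C@@H](O)[C@H]2O)c(SCc2ccccc2)n1`; in this assay compound 2 gives 6200 nM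
compound 3 `O=c1ccn([C@@H]2O[C@H](COP(=O)(O)O)[C@@H](O)[C@H]2O)c(SCc2ccccc2)n1`; in this assay compound 3 gives >= 100000 nM, which is a limit of the assay and not a number (the limit of >= 100000 nM in this assay, at which 1 of the 3 values shown sits)

Two changes connect the three measured compounds. From compound 2 to compound 1 the change is methoxy in place of benzylsulfanyl on an aromatic carbon, and it made a 6.8-fold lower number from compound 2 to compound 1 (0.83 log units; beyond the scatter). From compound 2 to compound 3 the change is a hydrogen atom in place of a group of 4 heavy atoms (3 oxygen, 1 phosphorus; no ring), on an oxygen, and it made an at least 16-fold higher number from compound 2 to compound 3 (1.20 log units; beyond the scatter); since compound 3 stands at a limit, the true size of that step is open.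

Compound 4 `COc1nc(=O)ccn1[C@@H]1O[C@H](COP(=O)(O)O)[C@@H](O)[C@H]1O` has not been measured in this assay. Compound 3 and compound 4 differ by methoxy in place of benzylsulfanyl on an aromatic carbon, the same change as from compound 2 to compound 1, at the same place. Compound 4 also relates to compound 1 by the loss of the same group that separates compound 2 from compound 3, though that pair is not broken down here.

Compound 4 is expected to sit at an at least 3.3-fold lower number from compound 3 to compound 4 (0.52 log units; beyond the scatter) from compound 3, resting on the step of a 6.8-fold lower number from compound 2 to compound 1 (0.83 log units; beyond the scatter) seen for the same change, with the limit of compound 3 (the limit of >= 100000 nM in this assay, at which 1 of the 3 values shown sits) leaving the starting point uncertain; the step of an at least 16-fold higher number from compound 2 to compound 3 (1.20 log units; beyond the scatter) applied to compound 1 points the same way. The estimate for compound 4 is 30000 nM, within 8000 nM to 120000 nM, and a limit-only result is possible.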

Compound 4, half-maximal effective concentration: 9900 nM
Compound 4: middle estimate off by 3.0-fold (0.48 log units), on the high side; the measured number falls inside the stated range.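

In this assay, methoxy in place of benzylsulfanyl again brings a lower number on the core that carries the shorter phosphate group (an at least 10-fold lower number from compound 3 to compound 4 (1.00 log units; beyond the scatter)), and a hydrogen atom in place of the group of phosphorus and oxygen atoms again brings a higher number, now on the methoxy core (an 11-fold higher number from compound 1 to compound 4 (1.04 log units; beyond the scatter)). The methoxy change thus keeps its direction on both cores, but whether its size carries over is not shown: the same change on two cores in this assay, a 6.8-fold lower number (0.83 log units; beyond the scatter) from compound 2 to compound 1 and an at least 10-fold lower number (1.00 log units; beyond the scatter) from compound 3 to compound 4; the limit leaves it open whether they differ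
The loss of the phosphorus-bearing group also keeps its direction, with the same question about size left unanswered: the same change on two cores in this assay, an at least 16-fold higher number (1.20 log units; beyond the scatter) from compound 2 to compound 3 and an 11-fold higher number (1.04 log units; beyond the scatter) from compound 1 to compound 4; the limit leaves it open whether they differ

These notes rest on a single pair of cores and a single read-out, so they give direction for these four compounds only and no general rule for the series. Still open, from the compounds shown here alone, is whether the same direction would hold with an ethoxy group or an amine in place of methoxy on the aromatic carbon, or with a triphosphate in place of the diphosphate chain.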